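The compounds below may be only part of what the source reports. "The series", "measured", "known", "first", "only" and "open" are said of these compounds alone.

Compound 3 `CCSC(=O)C1=C(C)NC(=O)NC1c1ccco1` belongs to a small set of three compounds sharing one core. In an assay on membranes from HEK293 cells for displacement of a labelled ligand from adenosine receptor A2b (Homo sapiens), read by scintillation counting, with a stated time of 30 min, tested at 1 uM (a higher number here means more inhibition at the concentration tested (going by the name of the read-out), a lower number less inhibition), compound 3 gives 29%, the second highest number of the three. Compound 2 `CCN(CC)C(=O)C1=C(C)NC(=O)NC1c1ccco1` gives 31%, and a number 2 percentage points lower from compound 2 to compound 3 (within the scatter), so the two are indistinguishable here. Compound 1 `CCNC(=O)C1=C(C)NC(=O)NC1c1ccco1` gives 1%, with a number 30 percentage points higher from compound 1 to compound 2 (beyond the scatter) and a number 28 percentage points higher from compound 1 to compound 3 (beyond the scatter), both modest gains.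

Compound 4 `CC1=C(C(=O)SC(C)C)C(c2ccco2)NC(=O)N1` differs from compound 3 by methyl in place of hydrogen on a saturated chain carbon bound to a saturated chain carbon and a sulfur. Within the data shown here, no measured step changes this chain, so nothing directly bears on the move; the only comparable addition of carbon is a number 30 percentage points higher from compound 1 to compound 2 (beyond the scatter), at a different place. A step of a number 3 percentage points higher from compound 3 to compound 4 (within the scatter) is therefore expected, within the scatter. Compound 4 is estimated at 32%, ranging from 15% to 50%.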

Compound 4, a percentage reported as inhibition, at one concentration (the size of the read-out at that concentration, not a potency): 22%
Estimate against measurement, compound 4: 10 percentage points above; the measured number falls inside the stated range.
By their numbers in this assay, from the lowest: compound 1; then compounds 4, 3 and 2 (each within the scatter of the next).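

Turning ethylsulfanyl into isopropylsulfanyl leaves the read-out unchanged within the scatter (a number 7 percentage points lower from compound 3 to compound 4 (within the scatter)), so this chain accepts one added methyl on the carbon bound to sulfur. The isopropylsulfanyl group also stays level with diethylamino (a number 9 percentage points lower from compound 2 to compound 4 (within the scatter)) and keeps a modest gain over ethylamino (a number 21 percentage points higher from compound 1 to compound 4 (beyond the scatter)). No available evidence explains these numbers.

On these data alone, whether a longer chain such as butyl, or a ring such as phenyl, on the sulfur would shift the number remains open. So does the effect of changing the furan-bearing part of the shared core.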